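A 4-methylpiperazin-1-yl group enters at compound 3

The compounds below may be only part of what the source reports. "The series", "measured", "known", "first", "only" and "open" are said of these compounds alone.

Values in a functional assay on NB1 cells (Homo sapiens) for cytotoxicity, read by MTT assay, with a stated time of 3 days; on this read-out higher numbers stand for weaker inhibition and lower numbers for stronger inhibition:
Compound 1 `CNc1nc(SCc2nc3ccccc3[nH]2)nc(-c2ccccc2)c1C#N`: 4.46 nM
Compound 2 `N#Cc1c(NC(N)=S)nc(SCc2nc3ccccc3[nH]2)nc1-c1ccccc1`: 11.9 nM
Compound 3 `CN1CCN(c2nc(SCc3nc4ccccc4[nH]3)nc(-c3ccccc3)c2C#N)CC1`: not yet measured

Compound 2, at 11.9 nM, holds the higher of the two numbers and so is the weaker inhibitor of the pair. Compound 3 keeps the shared core and changes one substituent: a group of 7 heavy atoms (5 carbon, 2 nitrogen; one six-membered non-aromatic ring with 2 hetero atoms) in place of a group of 4 heavy atoms (1 carbon, 2 nitrogen, 1 sulfur; no ring), on an aromatic carbon. The new group sits on an aromatic carbon, ortho to a cyano group. Among the compounds with values here, only one measured step bears on this place, a 2.7-fold higher number from compound 1 to compound 2 (0.43 log units; beyond the scatter), and it was modest. Within the data shown here, no measured compound carries a ring there, so the direction is poorly fixed. In this assay a small upward step is expected, probably not clearly beyond the scatter. The estimate for compound 3 is 20 nM, with an expected range of 4 nM to 90 nM. This estimate means a 1.7-fold higher number from compound 2 to compound 3 (0.23 log units; within the scatter).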

Compound 3, half-maximal inhibitory concentration: 2.4 nM
For compound 3 the middle estimate is 8.3-fold (0.92 log units) above the measured one; the measured number lies below the stated range.
By their numbers in this assay, from the lowest: compounds 3 and 1 (each within the scatter of the next); then compound 2.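

In this assay, the aromatic carbon ortho to a cyano group proves able to carry a ring: 4-methylpiperazin-1-yl in place of the ring-free group of compound 2 gives (a 5.0-fold lower number from compound 2 to compound 3 (0.70 log units; beyond the scatter)), so the upward step seen earlier does not extend to every larger group here. Set against methylamino, the same ring stays within the scatter (a 1.9-fold lower number from compound 1 to compound 3 (0.27 log units; within the scatter)), so these two groups cannot be told apart at this position, and only compound 2 stands off from both. Nothing measured here explains these steps.

From the compounds shown here alone, it remains open whether the ring itself or its second nitrogen matters, which a morpholin-4-yl or piperidin-1-yl group at this place could show. A plain piperazin-1-yl group would likewise test what the methyl on that nitrogen contributes.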